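A Dimethoxyphenyl Variant Measured Against Its Chlorophenyl Parent

The source may report more compounds than this note shows. Statements on the series, on what has been measured and on what is new or still open speak of the compounds shown alone.

Compound 1, `O=c1c2ccccc2c(Cc2ccc(Cl)cc2)nn1-c1ccc([N+](=O)[O-])cc1`: 29000 nM
Compound 2, `Cn1nc(Cc2ccccc2)c2ccccc2c1=O`: <= 10000 nM, a limit of the assay
Compound 3, `Oc1nnc(Cc2cccc3ccccc23)c2ccccc12`: 4400 nM

Three compounds sharing a core were measured in a functional assay on aorta with Alpha-1D adrenergic receptor (Rattus norvegicus) as the target; on this read-out lower numbers stand for an effect already at smaller amounts and higher numbers for an effect only at larger amounts of compound. Compound 1 gives 29000 nM in this assay, the highest of the two numbers available. Compound 3 gives 4400 nM, a lower number, and the gap to compound 1 lies beyond the usual scatter. For compound 2 the assay records only a limit, <= 10000 nM, and not a number; (the limit of <= 10000 nM in this assay, at which 1 of the 3 values shown sits). No pair among these three differs in a single place, so no measured step exists to guide what follows.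

Compound 4, `COc1ccc(Cc2nn(-c3ccc([N+](=O)[O-])cc3)c(=O)c3ccccc23)cc1OC`, has not yet been measured in this assay. It differs from compound 1 in one place: 3,4-dimethoxyphenyl in place of 4-chlorophenyl on a saturated chain carbon bound to an aromatic carbon. Since compounds 2 and 3 carry other groups on the same chain carbon and other substituents on the ring nitrogen, they offer no direct reading of this exchange. The step from compound 1 to compound 4 is therefore expected to be modest, with a lean toward a lower number, as a 1.9-fold lower number from compound 1 to compound 4 (0.29 log units; within the scatter). Compound 4 is estimated at 15000 nM, within a range from 4000 nM to 60000 nM.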

Compound 4, half-maximal effective concentration: > 100000 nM
Compound 4 ended at the assay's limit; the forecaster's own chance of this, stated with the estimate: 25%; middle value at least 6.6-fold (0.82 log units) away from the limit.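

In this assay compound 4 gives > 100000 nM as a limit of the assay and not a number. Within the data shown here, the exchange of 4-chlorophenyl for 3,4-dimethoxyphenyl on a saturated chain carbon bound to an aromatic carbon gives an at least 3.4-fold higher number from compound 1 to compound 4 (0.53 log units; beyond the scatter) as the first single-place step in this set, showing that the group held at this position matters in this read-out, while the limit leaves the full size of the step unknown. The entering group has more heavy atoms and brings hydrogen-bond acceptors where 4-chlorophenyl has none, but nothing shown here ties either difference to the higher number.

Going by these compounds, whether the higher number follows from losing the chlorine or from gaining the methoxy groups stays open, and an amine or a carboxylic acid on the phenyl ring, or a longer chain at this place, would help to separate the two readings. Among these compounds, also open is whether the same exchange would give a step of this direction with another substituent on the ring nitrogen, such as the one in compound 2.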